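The source may report more compounds than this note shows. Statements on the series, on what has been measured and on what is new or still open speak of the compounds shown alone.

Compound 1 `Cc1c(C(=O)Nc2ccc(Oc3ncnc4[nH]cc(-c5ccccc5)c34)c(F)c2)c(=O)c2ccccc2n1C` gives in an assay on isolated protein for inhibition of tyrosine-protein kinase receptor UFO (Homo sapiens), read by FRET and Z'-LYTE, with a stated time of 1.5 h (on this read-out lower numbers stand for stronger inhibition and higher numbers for weaker inhibition), a value of > 10000 nM, which is a limit of the assay rather than a number.
Compound 2 `Cc1c(C(=O)Nc2ccc(Oc3ncnc4[nH]cc(-c5ccccc5)c34)c(F)c2)c(=O)c2cc(C(C)C)ccc2n1C` gives in this assay 26 nM.
Compound 3 `CCCc1ccc2c(c1)c(=O)c(C(=O)Nc1ccc(Oc3ncnc4[nH]cc(-c5ccccc5)c34)c(F)c1)c(C)n2C` gives in this assay 61 nM.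

Among the two measured numbers, compound 3 holds the higher one, with compound 2 nearest; compound 1 contributes only a limit. Compound 4 `Cc1c(C(=O)Nc2ccc(Oc3ncnc4[nH]cc(-c5ccccc5)c34)c(F)c2)c(=O)c2cc(OC(F)(F)F)ccc2n1C` differs from compound 3 by trifluoromethoxy in place of propyl on an aromatic carbon. The measured steps at this aromatic carbon show that having a group there rather than hydrogen matters greatly: an at least 380-fold lower number from compound 1 to compound 2 (2.58 log units; beyond the scatter) and an at least 160-fold lower number from compound 1 to compound 3 (2.21 log units; beyond the scatter), while the exchange of one such group for another was smaller, as a 2.3-fold higher number from compound 2 to compound 3 (0.37 log units; beyond the scatter). Since compound 4 keeps a group on that carbon, a number near compound 3, possibly somewhat higher, is expected, and the expected step is a 2.5-fold higher number from compound 3 to compound 4 (0.39 log units; beyond the scatter). Compound 4 is estimated at 150 nM, within a range from 40 nM to 1500 nM.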

Compound 4, half-maximal inhibitory concentration: 74 nM
Compound 4: middle estimate off by 2.0-fold (0.31 log units), on the high side, and the stated range covers the measured number.
By their numbers in this assay, from the lowest: compound 2; then compounds 3 and 4 (each within the scatter of the next). At a limit, above all of these: compound 1.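

Trifluoromethoxy, a group with oxygen and fluorine, serves here much as propyl does, with a 1.2-fold higher number from compound 3 to compound 4 (0.08 log units; within the scatter), so the group on this aromatic carbon need not be made of carbon alone. Against isopropyl, the result is a 2.8-fold higher number from compound 2 to compound 4 (0.45 log units; beyond the scatter), while against hydrogen it is an at least 130-fold lower number from compound 1 to compound 4 (2.13 log units; beyond the scatter). That last step rests on compound 1, whose value is a limit of the assay and not a number: the limit of > 10000 nM in this assay, at which 1 of the 4 values shown sits.

The compounds shown leave open how small a group on this carbon can be, as with methyl or a single fluorine. On these data alone, whether an amine or a carboxylic acid is accepted there also remains open.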